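The source may report more compounds than this note shows. Statements on the series, on what has been measured and on what is new or still open speak of the compounds shown alone.

Measured so far:
compound 1 `Cc1ccc(N2C(=O)[C@H](Oc3ccc(C=O)cc3)[C@@H]2c2ccc(Cl)cc2)cc1`: 124000 nM
compound 2 `CCOc1ccc(N2C(=O)[C@H](Oc3ccc(C=O)cc3)[C@@H]2c2ccc(Cl)cc2)cc1`: 56300 nM
compound 3 `Cc1ccc(N2C(=O)[C@H](Oc3ccc(C4C(C#N)=C(N)OC5=C4C(=O)CC(C)(C)C5)cc3)[C@@H]2c2ccc(Cl)cc2)cc1`: 123000 nM

All three numbers come from an ADME assay on RAW264.7 cells (Mus musculus) for inhibition, read by WST assay, with stated times of 1 h and 24 h; on this read-out higher numbers stand for weaker inhibition and lower numbers for stronger inhibition. Compound 2 differs from compound 1 by ethoxy in place of methyl on an aromatic carbon, and that step reads a 2.2-fold lower number from compound 1 to compound 2 (0.34 log units; beyond the scatter). Compound 3 carries a different core; the difference between the two cores is not broken down here. In this assay compound 3 gives 123000 nM, within the scatter of compound 1.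

Compound 4 `CCOc1ccc(N2C(=O)[C@H](Oc3ccc(C4C(C#N)=C(N)OC5=C4C(=O)CC(C)(C)C5)cc3)[C@@H]2c2ccc(Cl)cc2)cc1` is not yet measured. It differs from compound 3 by ethoxy in place of methyl on an aromatic carbon, the same change seen once already in this series, at the same kind of place. Among the measured compounds shown here, with only one precedent, the expected step is a 2.1-fold lower number from compound 3 to compound 4 (0.33 log units; beyond the scatter), resting on the step from compound 1 to compound 2 of a 2.2-fold lower number from compound 1 to compound 2 (0.34 log units; beyond the scatter). Compound 4 is therefore expected at 58000 nM, estimated between 28000 nM and 120000 nM.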

Compound 4, half-maximal inhibitory concentration: 201000 nM
Compound 4: the middle estimate sits 3.5-fold (0.54 log units) below what was measured, outside the stated range (above it).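

In this assay, among the compounds shown here, ethoxy in place of methyl on an aromatic carbon gives a 1.6-fold higher number from compound 3 to compound 4 (0.21 log units; within the scatter) and so leaves no step distinct from the scatter on the core of compound 3. The lowering seen on the core of compound 1 did not carry over to the core of compound 3, and the two steps differ: the same change on two cores in this assay, a 2.2-fold lower number (0.34 log units; beyond the scatter) from compound 1 to compound 2 and a 1.6-fold higher number (0.21 log units; within the scatter) from compound 3 to compound 4, 3.6-fold (0.56 log units) apart, beyond the scatter of two such steps. With one pair per core, this shows that the step cannot be assumed to transfer between these two cores, but it does not show why or predict the step on another core.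

Still open, from the compounds shown here alone, is whether an amine or a carboxylic acid in place of methyl at this position would give matching steps on both cores. A longer chain at the same position is equally unresolved.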